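A few compounds are considered here, and "the series" means these few. Any claim that something is new, unique, unknown or untested is made for them only; others in the source may bear on it.

Measured so far in an ADME assay on microsomes from liver (Mus musculus) for metabolic stability, read by LC-MS, using NADPH, with a stated time of 10 min, tested at 10 uM; on this read-out lower numbers stand for a shorter-lived compound and higher numbers for a longer-lived compound:
- Compound 1 `Nc1ncnc2c1c(Oc1cc(C(F)(F)F)ccn1)nn2C1CC1`: > 2.41 h
- Compound 2 `Nc1ncnc2c1c(Oc1cc(O)ccn1)nn2C1CCC(F)(F)CC1`: 1.13 h

Compound 1, at > 2.41 h, stands at a limit of the assay and not at an exact number. Compound 3 `CO[C@H]1CC[C@@H](n2nc(Oc3cc(C(F)(F)F)ccn3)c3c(N)ncnc32)CC1` keeps the core of compound 1 and carries 4-methoxycyclohexyl in place of cyclopropyl on an aromatic nitrogen. Within the data shown here, no measured step shows what such a change does in this assay. Among the measured compounds shown here, a modest fall toward a shorter-lived compound is expected, with compound 2 at 1.13 h as the only exact value to lean on. The estimated step is an at least 2.0-fold lower number from compound 1 to compound 3 (0.30 log units; that floor lies within the scatter). For compound 3 the expected half-life is 1.2 h, with an estimated range of 0.5 h to 2.8 h.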

Compound 3, half-life: 0.0333 h
For compound 3 the middle estimate is 36-fold (1.56 log units) above the measured one; the whole stated range lies above it.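

Among these compounds, on the aromatic nitrogen, 4-methoxycyclohexyl in place of cyclopropyl is the first single-place change seen in this assay, and it gives an at least 72-fold lower number from compound 1 to compound 3 (1.85 log units; beyond the scatter). The half-life of this series therefore depends strongly on the group at this position, at least for this pair. That step is a floor and not an exact size, since compound 1 stands at a limit of the assay: the limit of > 2.41 h in this assay, at which 1 of the 3 values shown sits.

The compounds shown leave open whether the step belongs to the six-membered ring or to its methoxy group, which a plain cyclohexyl on the same nitrogen would help to separate. Compound 2 differs from compound 3 in more than one place and does not settle this.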